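This account rests on a few compounds, and the source may have more. Where it says the series, first, only, none or still open, it means among the compounds named here.

In a functional assay on COLO 205 cells (Homo sapiens) for antiproliferative activity (a lower number here means a stronger inhibitor of growth, a higher number a weaker inhibitor of growth), three compounds sharing one core have been measured. Compound 1 `COCCCCCCCCCCCCCCC/C=C1\CC(CO)(COC(=O)C(C)(C)C)OC1=O` gives 0.118 ug/mL, compound 2 `COC(=O)CCCCCCCCCCCCCC/C=C1\CC(CO)(COC(=O)C(C)(C)C)OC1=O` gives 3.86 ug/mL, and compound 3 `CC(C)(C)C(=O)OCC1(CO)C/C(=C\CCCCCCCCCCCO)C(=O)O1` gives 2.49 ug/mL. The data show a 1.6-fold lower number from compound 2 to compound 3 (0.19 log units; within the scatter), which leaves those two level, and a 21-fold higher number from compound 1 to compound 3 (1.32 log units; beyond the scatter), which sets compound 3 well apart from the low number of compound 1.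

Compound 4 `CC(=O)OCCCCCCCCCCCCCCC/C=C1\CC(CO)(COC(=O)C(C)(C)C)OC1=O` departs from compound 3 at the end of the chain, with 4-acetoxybutyl in place of hydroxy on a saturated chain carbon, ten or more bonds along the chain from a double-bonded chain carbon.

All three measured steps concern this same place. The end group clearly matters, as the data show a 33-fold higher number from compound 1 to compound 2 (1.51 log units; beyond the scatter) when methoxycarbonyl stands in place of methoxymethyl. The entering group carries a carbonyl, as does the 3-(methoxycarbonyl)propyl of compound 2, which gives 3.86 ug/mL, so that compound is taken as the nearer guide. The 4-methoxybutyl of compound 1 leaves some chance of a lower number. In this assay, the expected result is a 1.7-fold lower number from compound 3 to compound 4 (0.22 log units; within the scatter), with no clear step beyond the scatter anticipated. For compound 4 the estimated value is 1.5 ug/mL, with an expected range of 0.3 ug/mL to 6 ug/mL.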

Compound 4, concentration for 50% growth inhibition: 2.1 ug/mL
Compound 4: middle estimate off by 1.4-fold (0.15 log units), on the low side, and the stated range covers the measured number.
By their numbers in this assay, from the lowest: compound 1; then compounds 4, 3 and 2 (each within the scatter of the next).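

In this assay, compound 4 gives the closest comparison yet with the low number of compound 1: the only difference is acetyl in place of methyl on an oxygen on a saturated carbon, and the result is an 18-fold higher number from compound 1 to compound 4 (1.25 log units; beyond the scatter). The other two new steps are small, with 4-acetoxybutyl in place of hydroxy giving a 1.2-fold lower number from compound 3 to compound 4 (0.07 log units; within the scatter) and acetoxymethyl in place of methoxycarbonyl giving a 1.8-fold lower number from compound 2 to compound 4 (0.26 log units; within the scatter), so among the four chain ends shown, the acetoxy, methoxycarbonyl and hydroxy ends sit level and only the methoxy end stands apart. Nothing available explains this gap.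

As far as these compounds go, whether the low number belongs to the methoxy end alone remains open, and an ethoxy or benzyloxy end, or a free hydroxy, an amine or a carboxylic acid on a chain as long as that of compound 1, would bear on this. From the compounds shown here alone, it also remains open whether a methoxy end would keep its low number on the shorter chain of compound 3.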